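Swapping the aryl group on sulfur in two related series

The source may report more compounds than this note shows. Statements on the series, on what has been measured and on what is new or still open speak of the compounds shown alone.

Compound 1 `Cc1cc(C)cc(SCc2ccc(/C=C/C(=O)Nc3ccccc3N)cc2)c1`, compound 2 `Nc1ccccc1NC(=O)/C=C/c1ccc(CSc2ccc(Cl)cc2)cc1` and compound 3 `Nc1ccccc1NC(=O)c1ccc(CSc2ccc(Cl)cc2)cc1` were tested in a functional assay on A-375 cells (Homo sapiens) for inhibition, read by CCK-8 assay, with a stated time of 72 h, tested at 2 uM; on this read-out higher numbers stand for more inhibition of growth at the one concentration tested and lower numbers for less inhibition of growth. Compound 1 gives 8.78%, compound 2 gives 13.4%, and compound 3 gives 25.3%, the highest of the three. The difference between the cores of compound 2 and compound 3 is not broken down here. From compound 2 to compound 1 the change is 3,5-dimethylphenyl in place of 4-chlorophenyl on a sulfur, and the step was a number 4.6 percentage points lower from compound 2 to compound 1 (within the scatter). Compound 4 `Cc1cc(C)cc(SCc2ccc(C(=O)Nc3ccccc3N)cc2)c1` has not yet been measured; it arises from compound 3 by the same change, (3,5-dimethylphenyl in place of 4-chlorophenyl on a sulfur). Because the earlier step of a number 4.6 percentage points lower from compound 2 to compound 1 (within the scatter) lay within the scatter, only a small step is expected here, a number 4.3 percentage points lower from compound 3 to compound 4 (within the scatter). Compound 4 is therefore estimated at 21%, most likely between 9% and 33%.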

Compound 4, percent growth inhibition at one concentration: 48.5%
Estimate against measurement, compound 4: 27.5 percentage points below; measured number above the stated range.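

In the core of compound 3, putting 3,5-dimethylphenyl in place of 4-chlorophenyl on the sulfur gave a number 23.2 percentage points higher from compound 3 to compound 4 (beyond the scatter). The result of this change therefore does not transfer reliably between these two cores: the same change on two cores in this assay, a number 4.6 percentage points lower (within the scatter) from compound 2 to compound 1 and a number 23.2 percentage points higher (beyond the scatter) from compound 3 to compound 4, 27.8 percentage points apart, beyond the scatter of two such steps. These two pairs show that a step measured on one core can be a poor guide to the other, but they do not explain the gap or predict the step on a third core.

Going by these compounds, it remains open how either core would respond if a saturated amine or a carboxylic acid took the place of the aryl group on the sulfur. A longer chain in that place also remains to be explored.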